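A few compounds are considered here, and "the series" means these few. Any claim that something is new, unique, unknown or untested is made for them only; others in the source may bear on it.

In a functional assay (strain AB) with Danio rerio as the target, read by microscopy, with a stated time of 1 h (on this read-out higher numbers stand for an effect only at larger amounts of compound and lower numbers for an effect already at smaller amounts), three compounds have been measured so far. Compound 1 `C[N+]1(CC2CCCCC2)CCc2c(sc(NC(=O)Nc3ccc(Cl)cc3)c2C(N)=O)C1` gives 100 nM. Compound 2 `CCN1CCc2c(sc(NC(=O)NCC3CCCO3)c2C(N)=O)C1` gives > 25000 nM, which is a limit of the assay and not a number. Compound 3 `NC(=O)c1c(NC(=O)Nc2ccc(Cl)cc2)sc2c1CCN(CC1CCCCC1)C2` gives 1890 nM, the higher of the two actual numbers, and its gap to compound 1 lies beyond the usual scatter. Compound 4 `COCCCN1CCc2c(sc(NC(=O)Nc3ccc(Cl)cc3)c2C(N)=O)C1` has not yet been measured. Its difference from compound 3 is 2-methoxyethyl in place of cyclohexyl on a saturated chain carbon bound to an amine nitrogen in a ring. Among the measured compounds shown here, no measured pair shows this change alone, so a moderate rise in the number, beyond the scatter, is only an expectation. The estimated change is a 2.6-fold higher number from compound 3 to compound 4 (0.42 log units; beyond the scatter). For compound 4 the expected value is 5000 nM, with an estimated range of 1500 nM to 20000 nM.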

Compound 4, half-maximal effective concentration: 2400 nM
Compound 4: middle estimate off by 2.1-fold (0.32 log units), on the high side; the range from low to high includes it.
By their numbers in this assay, from the lowest: compound 1; then compounds 3 and 4 (each within the scatter of the next). At a limit, above all of these: compound 2.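

In this assay, putting 2-methoxyethyl in place of cyclohexyl gives a 1.3-fold higher number from compound 3 to compound 4 (0.10 log units; within the scatter). At this position, on a saturated chain carbon bound to an amine nitrogen in a ring, the carbon ring and the open chain carrying an oxygen therefore cannot be told apart by this read-out. Nothing measured here explains that outcome.

On these data alone, whether a chain ending in an amine or a carboxylic acid would fare the same at this place stays open. So does whether this swap would give a similar result on compound 1.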